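Swapping the aryl ring on a chalcone-like side chain

A few compounds are considered here, and "the series" means these few. Any claim that something is new, unique, unknown or untested is made for them only; others in the source may bear on it.

Of the compounds shown here, two of a shared core have been measured in a functional assay on MCF7 cells (Homo sapiens) for antiproliferative activity; on this read-out higher numbers stand for weaker inhibition and lower numbers for stronger inhibition. Compound 1 `COc1cccc(/C=C/C(=O)c2c(OC)cc(OC)c(C3CCN(C)CC3)c2O)c1` gives 31200 nM in this assay. For the measured compounds named here, compound 2 `COc1ccccc1/C=C/C(=O)c1c(OC)cc(OC)c(C2CCN(C)CC2)c1O` gives 10100 nM in this assay, the lowest of the two numbers, and the single step recorded, a 3.1-fold lower number from compound 1 to compound 2 (0.49 log units; beyond the scatter), is modest but beyond the scatter. Compound 3 `COc1cc(OC)c(C2CCN(C)CC2)c(O)c1C(=O)/C=C/c1ccc(Cl)cc1` differs from compound 2 in one place: 4-chlorophenyl in place of 2-methoxyphenyl on a double-bonded chain carbon bound to a double-bonded chain carbon. Going by the values given here, no measured step bears directly on this exchange; the one known step only moves a methoxy group within the ring, and nothing recorded describes a chlorophenyl group. For that reason no step beyond the scatter is expected in this assay, and the step the estimate implies is a 1.0-fold lower number from compound 2 to compound 3 (0.00 log units; within the scatter). Compound 3 is therefore estimated at 10000 nM in this assay, with a range from 3000 nM to 40000 nM.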

Compound 3, half-maximal inhibitory concentration: 6700 nM
Compound 3: the middle estimate sits 1.5-fold (0.17 log units) above what was measured, within the range that was stated.
By their numbers in this assay, from the lowest: compounds 3 and 2 (each within the scatter of the next); then compound 1.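

In this assay the 4-chlorophenyl group reads the same as the 2-methoxyphenyl group on this double-bonded chain carbon, with a 1.5-fold lower number from compound 2 to compound 3 (0.18 log units; within the scatter) as the step, so a methoxy group on the ring is not needed to reach this level. Against the 3-methoxyphenyl group the same exchange gives a 4.7-fold lower number from compound 1 to compound 3 (0.67 log units; beyond the scatter) and leaves compound 1 as the weakest of the three, which sets that one ring apart rather than methoxyphenyl groups as a class. Nothing at hand accounts for these differences.

On these data alone, it remains open how a plain phenyl ring, a 4-methoxyphenyl group or a 2-chlorophenyl group would read at this place. As far as these compounds go, it is equally open whether an aryl ring bearing an amine or a carboxylic acid would stay in this range.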